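The source may report more compounds than this note shows. Statements on the series, on what has been measured and on what is new or still open speak of the compounds shown alone.

Working notes on the series.

Compound 1 `O=C(Nc1ccc(Sc2nc3ccccc3s2)c(Cl)c1)c1ccccc1O` is the starting point. In an assay for inhibition of HSP60/HSP10 (Homo sapiens), with a stated time of 60 min (a lower number here means a stronger inhibitor, a higher number a weaker inhibitor), compound 1 gives > 100000 nM, which is a limit of the assay and not a number. Compound 2 `O=C(Nc1ccccc1)c1cccc(Br)c1O` is a second member of the set. In this assay compound 2 gives > 100000 nM, again a limit rather than a number. Compound 3 `O=C(Nc1ccc(Sc2nc3ccccc3s2)cc1)c1ccccc1O` differs from compound 1 in one place, hydrogen in place of chloro on an aromatic carbon. In this assay compound 3 gives > 100000 nM, also a limit. For the measured compounds named here, the single step between measured compounds, a step that the two limits leave unreadable from compound 1 to compound 3, therefore has no readable size, because of the limit of > 100000 nM in this assay, at which 3 of the 3 values shown sit.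

Compound 4 `O=C(Nc1ccc(Sc2nc3ccccc3s2)c(Cl)c1)c1cc(Br)cc(Br)c1` is not yet measured. It arises from compound 1 by 3,5-dibromophenyl in place of 2-hydroxyphenyl on a carbonyl carbon. Going by the values given here, no measured step bears on a change at the carbonyl carbon; the only measured step, from compound 1 to compound 3, concerns the chloro on an aromatic carbon and is itself unreadable. Among the compounds with values here, compound 1 thus stands only at a limit, and every value in this assay so far sits there.

Expectation: the step that the limit leaves unreadable from compound 1 to compound 4 is estimated to be none beyond the scatter, with a further limit the most likely outcome. Compound 4 is expected to give about 150000 nM, within a range from 50000 nM to 500000 nM.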

Compound 4, half-maximal inhibitory concentration: > 100000 nM
Compound 4 ended at the assay's limit (the forecaster's own chance of this, stated with the estimate: 80%); the middle value lies beyond the limit too.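

In this assay compound 4 gives > 100000 nM, a limit and not a number, so the change from compound 1 to compound 4 has no readable size because both compounds sit at the same limit: the limit of > 100000 nM in this assay, at which 4 of the 4 values shown sit.

The compounds shown leave open which structural change, if any, would bring a value within the readable range of this assay.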